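From an Aromatic Amine to an Aziridine Sulfonamide

The source may report more compounds than this note shows. Statements on the series, on what has been measured and on what is new or still open speak of the compounds shown alone.

Of the compounds shown here, two built on a shared core have been measured in an assay on HEK293 cells for binding affinity to Neuronal acetylcholine receptor; alpha4/beta2 (Homo sapiens); a lower number here means a stronger inhibitor, a higher number a weaker inhibitor. Compound 1 `c1ccc(Cc2nc3cc4c(cc3o2)C2CNCC4C2)cc1` gives 34 nM. Compound 2 `Nc1ccc2c(c1)C1CNCC2C1`, which carries an amino group on its aromatic ring, gives 100 nM in this assay. Of the two numbers, that of compound 2 is the higher, and its gap to compound 1 lies beyond the scatter of repeated measurements, so compound 1 is the stronger inhibitor of the pair.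

Compound 3 `O=S(=O)(c1ccc2c(c1)C1CNCC2C1)N1CC1` has not yet been measured. It differs from compound 2 in one place: a group of 6 heavy atoms (2 carbon, 1 nitrogen, 2 oxygen, 1 sulfur; one three-membered non-aromatic ring with 1 hetero atom) in place of one nitrogen atom, on an aromatic carbon. The group that leaves is small and carries a hydrogen-bond donor; the group that enters is larger and carries none.

For the measured compounds named here, no measured step of this kind exists in the data. Compound 3 is expected to give about 300 nM, with a range from 60 nM to 1500 nM. The expected step of a 3.0-fold higher number from compound 2 to compound 3 (0.48 log units; beyond the scatter) is a modest weakening, possibly within the scatter.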

Compound 3, inhibition constant: 2 nM
Estimate against measurement, compound 3: 150-fold (2.18 log units) above, outside the stated range (below it).
By their numbers in this assay, from the lowest: compound 3; then compound 1; then compound 2.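

In this assay, the aromatic carbon that carries the amino group in compound 2 accepts a far larger group without loss of binding: the aziridine sulfonamide brings a 50-fold lower number from compound 2 to compound 3 (1.70 log units; beyond the scatter). Compound 2 alone could not show this, and the step also shows that a hydrogen-bond donor on this carbon is not required for a low number, since the entering group has none. Nothing measured here accounts for the size of the step.

The compounds shown leave open whether the step belongs to the sulfonyl part or to the three-membered ring, a question that a dimethylamino sulfonamide or a methyl sulfone would address. They also leave open whether the same group would give a similar step on another aromatic carbon of the shared core.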